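Trimming a Methoxy from the Longest-Chain Compound

This account rests on a few compounds, and the source may have more. Where it says the series, first, only, none or still open, it means among the compounds named here.

The three measured compounds, with their values in a functional assay for agonist activity at follicle-stimulating hormone receptor (Homo sapiens), read by a luciferase reporter; on this read-out lower numbers stand for an effect already at smaller amounts and higher numbers for an effect only at larger amounts of compound:
compound 1, `CCCCCCCCN1CC(=O)N(C)[C@@H](Cc2ccc(-c3cc(OC)c(OC)c(OC)c3)cc2)C1=O`, gives 400 nM
compound 2, `CCCCCCCN1CC(=O)N(C)[C@@H](Cc2ccc(-c3cc(OC)c(OC)c(OC)c3)cc2)C1=O`, gives 2300 nM
compound 3, `CCCCCCN1CC(=O)N(C)[C@@H](Cc2ccc(-c3cc(OC)c(OC)c(OC)c3)cc2)C1=O`, gives 3000 nM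

Compound 1 stands at the lowest number of the three. Shortening its chain costs potency: the change a 5.8-fold higher number from compound 1 to compound 2 (0.76 log units; beyond the scatter) and the change a 7.5-fold higher number from compound 1 to compound 3 (0.88 log units; beyond the scatter) are both beyond the scatter, while the further shortening a 1.3-fold higher number from compound 2 to compound 3 (0.12 log units; within the scatter) is within it.

Compound 4, `CCCCCCCCN1CC(=O)N(C)[C@@H](Cc2ccc(-c3cc(OC)cc(OC)c3)cc2)C1=O`, keeps the full chain of compound 1 and alters the other end of the molecule instead: hydrogen in place of methoxy on an aromatic carbon. Going by the values given here, none of the measured steps touches this part of the molecule; all three concern the chain only, so they give no direct guide to what removing one methoxy group does in this assay. What can be said is that compound 4 shares the chain that gave compound 1 its low number, so the starting point is the best of the series.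

Among the compounds with values here, with no measured precedent for the aromatic change, the expectation is a modest loss: the step from compound 1 to compound 4 is estimated at a 2.5-fold higher number from compound 1 to compound 4 (0.40 log units; beyond the scatter). Compound 4 is therefore expected to give about 1000 nM, plausibly between 200 nM and 5000 nM.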

Compound 4, half-maximal effective concentration: 5000 nM
Compound 4: middle estimate off by 5.0-fold (0.70 log units), on the low side, and the stated range covers the measured number.
By their numbers in this assay, from the lowest: compound 1; then compounds 2, 3 and 4 (each within the scatter of the next, the first and the last beyond it).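

Going by these compounds alone, until this point only the chain had changed, so this is the first sign that the aromatic end of the molecule also counts in this assay as well. Going from 3,4,5-trimethoxyphenyl to 3,5-dimethoxyphenyl while the chain stays the same produces a large step (a 13-fold higher number from compound 1 to compound 4 (1.10 log units; beyond the scatter)). The change sits at a single place, the aromatic carbon para to a large group and ortho to two methoxy groups, and keeping the longest chain of the series does not make up for it; nothing measured here explains why this methoxy group matters.

Going by these compounds, it remains open whether another group on this carbon, such as hydroxyl, ethoxy or fluorine, would hold the number of compound 1 (400 nM) or whether the methoxy group is needed as it stands. Also open, on these data alone, are whether the same removal would cost as much on the shorter chains of compound 2 and compound 3, and whether a chain longer than that of compound 1 would win back what this change gives up.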